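The compounds below may be only part of what the source reports. "The series", "measured", "known", "first", "only" and "open" are said of these compounds alone.

- compound 1 `CCCCC#Cc1cc2cn([C@@H]3O[C@H](CO)[C@@H](O)[C@H]3O)c(=O)nc2o1`: > 144000 nM (a limit)
- compound 2 `CCCCC#Cc1cc2cn(C)c(=O)nc2o1`: > 217000 nM (a limit)
- compound 3 `CCCCCCCCCCC#Cc1cc2cn([C@H]3C[C@H](O)[C@@H](CO)O3)c(=O)nc2o1`: 36000 nM

In a functional assay on HEL cells (Homo sapiens) for cytotoxicity (a lower number here means that less compound is tolerated, a higher number that more compound is tolerated), compound 3 gives 36000 nM. Within the data shown here, this is the only actual number among the three. The other two values are limits. Compound 4 `CCCCC#Cc1cc2cn([C@H]3C[C@H](O)[C@@H](CO)O3)c(=O)nc2o1` is still unmeasured. It differs from compound 3 as follows: hydrogen in place of hexyl on a saturated chain carbon, four bonds along the chain from a triple-bonded carbon. In words, hydrogen stands in place of hexyl on a saturated chain carbon, four bonds along the chain from a triple-bonded carbon, so the chain is shorter.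

Compound 4 shares its chain with compound 1, whose > 144000 nM is a limit. It also shares that chain with compound 2, whose > 217000 nM is a limit. On that basis, an upward move beyond the scatter is expected, meaning more compound tolerated, with a 4.7-fold higher number from compound 3 to compound 4 (0.67 log units; beyond the scatter) as the expected step. For compound 4 the estimated value is 170000 nM, with an expected range of 70000 nM to 350000 nM.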

Compound 4, half-maximal cytotoxic concentration: > 150000 nM
Compound 4: only a limit was reported (the forecaster's own chance of this, stated with the estimate: 60%); the middle value is on the limit's open side.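

Among these compounds, compound 3 and compound 4 form the first pair that differs only in the chain, and in this assay the change to hydrogen in place of hexyl gives an at least 4.1-fold higher number from compound 3 to compound 4 (0.61 log units; beyond the scatter). Shortening the chain therefore goes with more compound tolerated when the 4-hydroxy-5-(hydroxymethyl)oxolan-2-yl group stays the same. The steps to compound 4 from compound 1 and compound 2 cannot be read, as each joins two limits.

As far as these compounds go, the full size of the step stays open, as compound 4 gives only a limit, > 150000 nM. An octyl chain in place of these two chains would help show whether the number falls gradually or abruptly with chain length.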